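Mirror images and a hydroxy for fluoro swap

This account rests on a few compounds, and the source may have more. Where it says the series, first, only, none or still open, it means among the compounds named here.

The read-out here is an assay on isolated protein for inhibition of tissue alpha-L-fucosidase (Bos taurus), tested at 1000 uM; on this read-out higher numbers stand for more inhibition at the one concentration tested (going by the name of the read-out) and lower numbers for less inhibition. Compound 1, `OC[C@@]1(c2ccc(F)cc2)NC[C@@H](O)[C@@H]1O`, gives 0% in this assay. Compound 2, `OC[C@]1(c2ccc(F)cc2)NC[C@H](O)[C@H]1O`, has the same atoms and bonds and is its mirror image; in this assay compound 2 gives 0%. The step of no change at the digits printed from compound 1 to compound 2 (within the scatter) shows no difference between the two, which fits the fact that they differ only in configuration (the fact that compounds 1 and 2 differ only in the configuration as drawn). Compound 2 therefore stands level with compound 1, with no inhibition recorded at the single concentration tested.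

Compound 3, `OC[C@]1(c2ccc(O)cc2)NC[C@H](O)[C@H]1O`, is drawn from compound 2 by a single change: hydroxy in place of fluoro on an aromatic carbon. Among the measured compounds shown here, the only measured step, between compound 1 and compound 2, involves no exchange of atoms, so it offers little direct guidance on a substituent swap; what it does show is that this assay is insensitive to this pair of cores, and both of them sit at the floor of the read-out. A step of a number 3 percentage points higher from compound 2 to compound 3 (within the scatter) is therefore expected, no change beyond the scatter. Compound 3 is estimated to give 3%, with a range of 0% to 18%.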

Compound 3, a percentage reported as inhibition, at one concentration (the size of the read-out at that concentration, not a potency): 0%
The estimate for compound 3 lay 3 percentage points above the measured number, and the stated range covers the measured number.
By their numbers in this assay, from the lowest: compounds 1, 2 and 3 (each within the scatter of the next).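

Replacing fluoro with hydroxy on an aromatic carbon, para to a group of 9 heavy atoms, brings in a hydrogen-bond donor and a hydrogen-bond acceptor where fluoro counted neither, yet the result in this assay is no change at the digits printed from compound 2 to compound 3 (within the scatter). On the core of compound 2, then, this swap at this position does not move the number off the bottom of the read-out, where compound 1 also sits. With the number resting there, a difference between fluoro and hydroxy too small to register at the one concentration tested cannot be ruled out, and nothing known about these compounds speaks to why the swap left the read-out unmoved.

Going by these compounds, it remains open whether any group at this position can raise the number at all, for instance an amine, a carboxylic acid or a longer chain in place of the hydroxy. Also open, on these data alone, is whether the mirror image of compound 3, which would pair with compound 1 through the same swap, would give the same reading.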